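The source may report more compounds than this note shows. Statements on the series, on what has been measured and on what is new or still open speak of the compounds shown alone.

Working notes on the series, read in a functional assay on NCI-H460 cells (Homo sapiens) for inhibition, read by MTT assay, with a stated time of 72 h; on this read-out lower numbers stand for stronger inhibition and higher numbers for weaker inhibition.

Compound 1 `COc1cc2c(Oc3ccc(NC(=O)c4nn(-c5ccccc5C)c(=O)cc4C)cc3F)ccnc2cc1OCCCN1CCC(C)CC1` gives 2260 nM. Within the data shown here, compound 2 `COc1cc2c(Oc3ccc(NC(=O)c4nn(-c5ccccc5C(F)(F)F)c(=O)cc4C)cc3F)ccnc2cc1OCCCN1CCC(C)CC1` gives 200 nM; the only single-point step so far is an 11-fold lower number from compound 1 to compound 2 (1.05 log units; beyond the scatter). Compound 3 `COc1cc2c(Oc3ccc(NC(=O)c4nn(-c5ccc(Cl)cc5Cl)c(=O)cc4C)cc3F)ccnc2cc1OCCCN1CCCCC1` gives 390 nM, which places it second highest of the three numbers: its value and that of compound 2 lie within the scatter of each other, while compound 1 stands well higher. Compound 2 and compound 3 differ in more than one place, so nothing beyond their two values can be said of that pair.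

Compound 4 `COc1cc2c(Oc3ccc(NC(=O)c4nn(-c5ccc(Cl)cc5Cl)c(=O)cc4C)cc3F)ccnc2cc1OCCCN1CCC(C)CC1` differs from compound 3 by methyl in place of hydrogen on a saturated ring carbon. Among the measured compounds shown here, no measured step touches this part of the molecule; compounds 1 and 2 both carry the 4-methylpiperidin-1-yl group, and their step concerns the aryl substituent only. With nothing to go on, the change from compound 3 to compound 4 is expected to give no change at the digits printed from compound 3 to compound 4 (within the scatter), that is no step beyond the scatter. Compound 4 is therefore estimated at 390 nM, within 150 nM to 1000 nM.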

Compound 4, half-maximal inhibitory concentration: 250 nM
Compound 4: middle estimate off by 1.6-fold (0.19 log units), on the high side, within the range that was stated.
By their numbers in this assay, from the lowest: compounds 2, 4 and 3 (each within the scatter of the next); then compound 1.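

In this assay, the change from piperidin-1-yl to 4-methylpiperidin-1-yl gives a 1.6-fold lower number from compound 3 to compound 4 (0.19 log units; within the scatter) and so shows that, with 2,4-dichlorophenyl on the aromatic nitrogen, methyl on this saturated ring carbon brings no step beyond the scatter. With 4-methylpiperidin-1-yl held constant, 2,4-dichlorophenyl in place of 2-(trifluoromethyl)phenyl gives a 1.3-fold higher number from compound 2 to compound 4 (0.10 log units; within the scatter) and 2,4-dichlorophenyl in place of 2-methylphenyl gives a 9.0-fold lower number from compound 1 to compound 4 (0.96 log units; beyond the scatter) and thus separates compound 1 from compound 4 while compound 2 and compound 4 stay within the scatter of each other. No measurement at hand bears on the cause of these steps.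

Going by these compounds, whether the methyl step holds with 2-methylphenyl or 2-(trifluoromethyl)phenyl on the aromatic nitrogen stays open. So does the reading of an ethyl or a hydroxyl on this ring carbon, or of a morpholin-4-yl in place of the piperidin-1-yl.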